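The source may hold more compounds than are shown below. What is called first, only, known or untested is meant among the compounds shown, and "the series" means these compounds.

Working notes on the series.

Compound 1 `CC(=O)OC[C@H]1O[C@@H](OC2=CC(=O)c3ccccc3C2=O)[C@H](OC(C)=O)[C@@H](OC(C)=O)[C@@H]1OC(C)=O` gives 4760 nM in a functional assay on MCF7 cells (Homo sapiens) for cytotoxicity, read by sulforhodamine B assay, with a stated time of 72 h; on this read-out higher numbers stand for weaker inhibition and lower numbers for stronger inhibition. Compound 2 `CC(=O)OC[C@H]1O[C@H](OC2=CC(=O)c3ccccc3C2=O)[C@H](OC(C)=O)[C@@H](OC(C)=O)[C@@H]1OC(C)=O` gives 3520 nM in this assay. Compound 3 `CC(=O)OC[C@H]1O[C@@H](n2cc(COC3=CC(=O)c4ccccc4C3=O)nn2)[C@H](OC(C)=O)[C@@H](OC(C)=O)[C@@H]1OC(C)=O` gives 3330 nM in this assay; of the three numbers in hand it is the lowest, but its gaps to compound 2 and to compound 1 are both within the scatter, so no ranking among the three is drawn. Going by the values given here, the single step that changes configuration alone is a 1.4-fold lower number from compound 1 to compound 2 (0.13 log units; within the scatter), and it is read as a pure stereochemical comparison because of the fact that compounds 1 and 2 differ only in the configuration as drawn.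

Compound 4 `CC(=O)OC[C@H]1O[C@@H](n2cc(COC3=CC(=O)c4ccccc4C3=O)nn2)[C@H](OC(C)=O)[C@@H](OC(C)=O)[C@H]1OC(C)=O` is the next candidate. the two compounds have the same atoms and bonds and differ only in configuration as drawn: 1 of 5 stereo elements differ; a stereocentre at a saturated ring carbon is drawn R in compound 3 and S in compound 4 Nothing leaves and nothing enters. Among the compounds with values here, the one measured step of the same kind, a 1.4-fold lower number from compound 1 to compound 2 (0.13 log units; within the scatter), stayed within the scatter, so the step from compound 3 is expected to behave alike: a 1.0-fold lower number from compound 3 to compound 4 (0.00 log units; within the scatter) in this assay, with no direction claimed beyond the scatter. Compound 4 is therefore estimated at 3300 nM, with a range from 1700 nM to 6600 nM.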

Compound 4, half-maximal inhibitory concentration: 4220 nM
Beside the measured number, compound 4's estimate is 1.3-fold (0.11 log units) below it, within the range that was stated.
By their numbers in this assay, from the lowest: compounds 3, 2, 4 and 1 (each within the scatter of the next).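

In this assay there is now a second configurational step, a 1.3-fold higher number from compound 3 to compound 4 (0.10 log units; within the scatter), this time on the structure of compound 3 rather than compound 1. It too reads as a pure stereochemical comparison: (the fact that compounds 3 and 4 differ only in the configuration as drawn). Inverting a stereocentre at a saturated ring carbon has now stayed within the scatter in both pairs, so neither pair shows any dependence on configuration in this assay, and this holds for these two pairs only.

The compounds shown leave open whether the remaining stereocentres would behave alike. They also leave open whether replacing the acetate groups with free hydroxyl groups, or with an amine, would move the number in this assay beyond the scatter.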